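The source may report more compounds than this note shows. Statements on the series, on what has been measured and on what is new or still open speak of the compounds shown alone.

Compound 1 `O=S(=O)(Cc1nc(-c2cccs2)c2sccc2n1)c1cccc(Cl)c1` belongs to a small set of compounds tested in an ADME assay on cells (Homo sapiens) for cytotoxicity, read by resazurin assay, with a stated time of 5 days; on this read-out higher numbers stand for lower toxicity in this test and lower numbers for higher toxicity in this test. In this assay compound 1 gives only a limit, > 50000 nM. Compound 2 `COc1ccc(-c2nc(CSc3cc(C)cc(C)c3)nc3ccsc23)cn1` likewise reaches only a limit, > 50000 nM. Compound 3 `COc1ccc(-c2nc(CC(O)c3cccc(Cl)c3)nc3ccsc23)cn1` gives a number in this assay, 31000 nM. For the measured compounds named here, the one measured step between compounds differing in a single place, an at least 1.6-fold lower number from compound 2 to compound 3 (0.20 log units; that floor lies within the scatter), shows that swapping the group on the saturated chain carbon changes little, and the limit of > 50000 nM in this assay, at which 2 of the 3 values shown sit, marks where most of the set sits.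

Compound 4 `COc1ccc(-c2nc(CS(=O)(=O)c3cccc(Cl)c3)nc3ccsc23)cn1` differs from compound 1 in the group on the fused two-ring core: 6-methoxypyridin-3-yl in place of thiophen-2-yl on an aromatic carbon. Going by the values given here, no measured step swaps an aromatic group at that place, so none bears on it directly; compounds 2 and 3 already carry 6-methoxypyridin-3-yl there and sit at or close to the limit. The step of a number no higher from compound 1 to compound 4 (the limit leaves the size open) is therefore expected to be none beyond the scatter. Compound 4 is expected to give about 50000 nM in this assay, estimated between 30000 nM and 100000 nM.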

Compound 4, half-maximal cytotoxic concentration: > 10000 nM
Compound 4 ended at the assay's limit; the forecaster's own chance of this, stated with the estimate: 70%; the middle value lies beyond the limit too.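

Compound 1 and compound 4 both end at limits in this assay rather than at numbers, so the step between them cannot be read. The compounds shown leave open whether 6-methoxypyridin-3-yl in place of thiophen-2-yl changes the read-out at all.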